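This account rests on a few compounds, and the source may have more. Where it says the series, first, only, none or still open, it means among the compounds named here.

Three compounds share a bicyclic diamine attached to a pyridine that carries an anilino group, and they were compared in an assay on cell membranes for displacement of a labelled ligand from Neuronal acetylcholine receptor; alpha4/beta2 (Rattus norvegicus); on this read-out higher numbers stand for weaker inhibition and lower numbers for stronger inhibition. Compound 1 `COc1ccc(Nc2cncc(N3CC4CC(C3)N4)c2)cc1` gives 0.0598 nM in this assay. Compound 2 `Fc1ccc(Nc2cncc(N3CC4CC(C3)N4)c2)cc1` gives 0.091 nM in this assay. Compound 1 and compound 2 differ in one place, (methoxy in place of fluoro on an aromatic carbon), and the step is a 1.5-fold lower number from compound 2 to compound 1 (0.18 log units; within the scatter), so the two values cannot be told apart. Compound 3 `Fc1ccc(Nc2ccc(N3CC4CC(C3)N4)cn2)cc1` gives 2.38 nM in this assay, the highest of the three numbers; its gaps to compound 2 and to compound 1 both lie beyond the usual scatter. Compound 3 is built from the same atoms as compound 2, joined differently, but the difference between the two cores is not broken down here.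

Compound 4 `COc1ccc(Nc2ccc(N3CC4CC(C3)N4)cn2)cc1` has not yet been measured. It stands to compound 3 as compound 1 stands to compound 2: the change is methoxy in place of fluoro on an aromatic carbon, at the same place as before, so it is the same change made on the other core. Since that change moved the number only within the scatter between compound 2 and compound 1, the step from compound 3 to compound 4 is expected to be similarly small, a 1.3-fold lower number from compound 3 to compound 4 (0.12 log units; within the scatter), resting on a 1.5-fold lower number from compound 2 to compound 1 (0.18 log units; within the scatter) alone. Compound 4 is therefore estimated at 1.8 nM in this assay, most likely between 0.7 nM and 4.5 nM.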

Compound 4, inhibition constant: 7.3 nM
Beside the measured number, compound 4's estimate is 4.1-fold (0.61 log units) below it, and the stated range ends below it.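

Measured in this assay, methoxy in place of fluoro on an aromatic carbon gives a 3.1-fold higher number from compound 3 to compound 4 (0.49 log units; beyond the scatter), and set beside the earlier pair, the change does not carry over at the same size from one core to the other: the same change on two cores in this assay, a 1.5-fold lower number (0.18 log units; within the scatter) from compound 2 to compound 1 and a 3.1-fold higher number (0.49 log units; beyond the scatter) from compound 3 to compound 4, 4.7-fold (0.67 log units) apart, beyond the scatter of two such steps. The effect of this change therefore depends on the core in these two pairs: it is a modest but real step on the core of compound 3, whereas compound 1 and compound 2 cannot be told apart on theirs. This does not show why the cores differ, and with a single pair on each core it does not show that any other change on the anilino ring would diverge in the same way.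

The compounds shown carry only fluoro or methoxy at this place, so it remains open how a chloro group, a nitrile or an amine there would behave on either core. Also open, going by these compounds, is whether a methyl group on the bicyclic diamine would leave the difference between the two cores as it stands in this assay.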